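From dimethylamino to chloro on a shared core

This account rests on a few compounds, and the source may have more. Where it says the series, first, only, none or still open, it means among the compounds named here.

Compound 1 `O=C(Nc1cccc(O)c1)c1ncc(-c2ccccc2)o1` gives > 30000 nM
Compound 2 `CN(C)c1ccc(NC(=O)c2ncc(-c3ccccc3)o2)cc1` gives > 30000 nM

Both compounds were tested in a functional assay on HepG2 cells (Homo sapiens) for cytotoxicity, read by CCK-8 assay; a higher number here means a weaker inhibitor, a lower number a stronger inhibitor. Compound 1 gives > 30000 nM, which is a limit of the assay and not a number. Compound 2 gives > 30000 nM, which is also a limit and not a number. Among the compounds with values here, compound 2 therefore has no exact place on the scale, and the only information available is the limit of > 30000 nM in this assay, at which 2 of the 2 values shown sit.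

Compound 3 `O=C(Nc1ccc(Cl)cc1)c1ncc(-c2ccccc2)o1` keeps the shared core but carries chloro in place of dimethylamino on an aromatic carbon. Within the data shown here, no two measured compounds differ in one place alone, so no measured step shows how large this change might be. In this assay a small step or none is expected, and any visible change would most likely be towards a stronger inhibitor. This expectation rests on compound 2 giving > 30000 nM, a limit. The estimated size of the change is an at least 1.2-fold lower number from compound 2 to compound 3 (0.07 log units; that floor lies within the scatter). For compound 3 the expected value is 25000 nM, with an estimated range from 8000 nM to 40000 nM.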

Compound 3, half-maximal inhibitory concentration: > 30000 nM
Compound 3 ended at the assay's limit (the forecaster's own chance of this, stated with the estimate: 60%); middle value at least 1.2-fold (0.07 log units) from the limit.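

No step can be read from compound 2 to compound 3 or from compound 1 to compound 3, because all three compounds sit at a limit and not at a number: the limit of > 30000 nM in this assay, at which 3 of the 3 values shown sit.

The compounds shown leave open how strongly each one acts in this assay, and whether chloro in place of dimethylamino on an aromatic carbon changes that at all.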